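Triazole benzylic group variation in EP4 antagonist series

The source may report more compounds than this note shows. Statements on the series, on what has been measured and on what is new or still open speak of the compounds shown alone.

Measured so far:
compound 1 `C[C@H](NC(=O)c1c(-c2ccccc2)nnn1Cc1ccccc1)c1ccc(C(=O)O)cc1` — 647 nM
compound 2 `COc1ccc(Cn2nnc(-c3ccccc3)c2C(=O)N[C@@H](C)c2ccc(C(=O)O)cc2)cc1F` — 29.8 nM

Two compounds have been run in a functional assay on CHO cells for antagonist activity at prostaglandin E2 receptor EP4 subtype (Homo sapiens), read by calcium flux, with a stated time of 15 min; on this read-out lower numbers stand for stronger inhibition and higher numbers for weaker inhibition. Compound 1 gives 647 nM, and compound 2 gives 29.8 nM. The single step shown is a 22-fold lower number from compound 1 to compound 2 (1.34 log units; beyond the scatter), the change being 3-fluoro-4-methoxyphenyl in place of phenyl on a saturated chain carbon bound to an aromatic nitrogen. Compound 2 therefore stands with the lowest number of the two shown, with compound 1 as its only neighbour and the gap beyond the scatter.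

Compound 3 `C[C@H](NC(=O)c1c(-c2ccccc2)nnn1CCOc1ccc(C(F)(F)F)cc1)c1ccc(C(=O)O)cc1` is the next compound at the same position: (4-(trifluoromethyl)phenoxy)methyl in place of 3-fluoro-4-methoxyphenyl on a saturated chain carbon bound to an aromatic nitrogen. Only a 22-fold lower number from compound 1 to compound 2 (1.34 log units; beyond the scatter) bears on this site, and it shows that the group on that carbon moves the number by a large amount. The entering (4-(trifluoromethyl)phenoxy)methyl group is not represented among the measured compounds, so no step sizes its effect directly; the substituted phenyl that drove the gain in compound 2 is removed. Compound 3 is accordingly expected to return part of the way toward compound 1, an expected step of a 5.0-fold higher number from compound 2 to compound 3 (0.70 log units; beyond the scatter). The estimate for compound 3 is 150 nM, with a range from 30 nM to 800 nM.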

Compound 3, half-maximal inhibitory concentration: 49.1 nM
Estimate against measurement, compound 3: 3.1-fold (0.49 log units) above; the measured number falls inside the stated range.
By their numbers in this assay, from the lowest: compounds 2 and 3 (each within the scatter of the next); then compound 1.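

In this assay the change from 3-fluoro-4-methoxyphenyl to (4-(trifluoromethyl)phenoxy)methyl on a saturated chain carbon bound to an aromatic nitrogen gives a 1.6-fold higher number from compound 2 to compound 3 (0.22 log units; within the scatter) and so leaves the two groups indistinguishable on this read-out, despite their different make-up. The entering group also gives a 13-fold lower number from compound 1 to compound 3 (1.12 log units; beyond the scatter) when set against plain phenyl, which shows that the large gain first seen with compound 2 is not tied to the 3-fluoro-4-methoxyphenyl group: two different substituted aromatic groups at this position both sit well clear of the unsubstituted phenyl of compound 1. Nothing at hand gives a reason for this tolerance or for the gain over phenyl.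

The compounds shown do not separate the contribution of the trifluoromethyl group from that of the phenoxy unit, so a plain phenoxymethyl group or a 4-chlorophenoxymethyl group would be needed to tell the two apart. Going by these compounds, how far the position tolerates other kinds of group also stays open, for example an amine, a carboxylic acid or a longer chain ending in the same substituted ring.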